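Aryl change on the amide-type nitrogen: outlook for compound 3

The source may report more compounds than this note shows. Statements on the series, on what has been measured and on what is new or still open speak of the compounds shown alone.

Measured so far:
compound 1 `CCN1CCc2c(c(C(C)(C)C)nn2C(=O)Nc2c(C)cccc2C)C1`: 73.7%
compound 2 `CCN1CCc2c(c(C(C)(C)C)nn2C(=O)Nc2ccc(C)cc2C)C1`: 71.1%

Both numbers come from a functional assay on the whole organism (strain Swiss albino) for inhibition, with Mus musculus as the target, in the writhing test, with a stated time of 30 min, at a dose of 100 mg/kg; a lower number here means less inhibition, a higher number more inhibition at the dose given (going by the name of the read-out). Within the data shown here, compound 2 stands within the scatter of compound 1: the only measured step, a number 2.6 percentage points lower from compound 1 to compound 2 (within the scatter), swaps one methyl pattern of the aryl group on the amide-type nitrogen for another and leaves the read-out essentially where it was. Among the measured compounds shown here, no other pair is available.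

Compound 3 `CCN1CCc2c(c(C(C)(C)C)nn2C(=O)Nc2cc(C)ccc2F)C1` differs from compound 2 by 2-fluoro-5-methylphenyl in place of 2,4-dimethylphenyl on an amide-type nitrogen. The step from compound 1 to compound 2 is the one that bears on this, as it is also a rearrangement of small substituents on the same aryl ring; it was within the scatter. For the measured compounds named here, the fluorine has no measured counterpart, so the expectation rests on that single step alone and is held loosely. Accordingly, no step beyond the scatter is expected in this assay, a number 3.1 percentage points lower from compound 2 to compound 3 (within the scatter). Compound 3 is estimated at 68%, with a range of 50% to 82%.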

Compound 3, a percentage reported as inhibition, in the whole organism at one dose (the size of the read-out at that dose, not a potency): 17.5%
Compound 3: middle estimate off by 50.5 percentage points, on the high side; measured number outside the range, below it.
By their numbers in this assay, from the lowest: compound 3; then compounds 2 and 1 (each within the scatter of the next).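

In this assay the aryl group on the amide-type nitrogen proves far less forgiving than the earlier pair suggested: 2-fluoro-5-methylphenyl gives a number 53.6 percentage points lower from compound 2 to compound 3 (beyond the scatter) in place of 2,4-dimethylphenyl and a number 56.2 percentage points lower from compound 1 to compound 3 (beyond the scatter) in place of 2,6-dimethylphenyl, both large steps beyond the scatter. The read-out at this position therefore depends on which small substituents the aryl ring carries, even though the step between the two dimethylphenyl groups, a number 2.6 percentage points lower from compound 1 to compound 2 (within the scatter) stayed within the scatter. Nothing available bears on the reason for the fall.

As far as these compounds go, compound 3 differs from compound 2 both in carrying fluorine and in the place of its methyl, so it remains open which of the two goes with the lower number. Also open, from the compounds shown here alone, is how this assay would respond to 2-chloro-5-methylphenyl, 2-methoxyphenyl or unsubstituted phenyl on the amide-type nitrogen.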